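This account rests on a few compounds, and the source may have more. Where it says the series, first, only, none or still open, it means among the compounds named here.

In a functional assay (trachea) with Cavia porcellus as the target (on this read-out higher numbers stand for weaker binding and lower numbers for tighter binding), two compounds on the shared core have been read so far: compound 1 `CO/N=C(\C(=O)N[C@@H]1C(=O)N2C(C(=O)[O-])=C(C[n+]3ccc4sccc4c3)CS[C@H]12)c1csc(N)n1` gives 43700 nM and compound 2 `CO/N=C(\C(=O)N[C@@H]1C(=O)N2C(C(=O)[O-])=C(C[n+]3ccc4c(c3)nc(C)n4C)CS[C@H]12)c1csc(N)n1` gives 3720000 nM. Compound 2 therefore holds the higher of the two numbers, which means the weaker binding in this small set.

Compound 3 `CO/N=C(\C(=O)N[C@@H]1C(=O)N2C(C(=O)[O-])=C(C[n+]3csc(CCO)c3C)CS[C@H]12)c1csc(N)n1` is the next to be read. The change is a group of 9 heavy atoms (6 carbon, 1 nitrogen, 1 oxygen, 1 sulfur; one five-membered aromatic ring with 2 hetero atoms) in place of a group of 11 heavy atoms (8 carbon, 3 nitrogen; one five-membered aromatic ring with 2 hetero atoms, one six-membered aromatic ring with 1 hetero atom), on a saturated chain carbon bound to a double-bonded ring carbon, with net charge +1 on both sides.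

Among the compounds with values here, one measured step bears on this place: an 85-fold higher number from compound 1 to compound 2 (1.93 log units; beyond the scatter), a large step beyond the scatter. It shows that the number in this assay can move strongly with the group at this place, but it rests on two compounds and a different pair of groups. Like the group of compound 1, the entering group contains sulfur, while the group of compound 2 does not. A move towards a lower number, beyond the scatter, is therefore expected, though probably not all the way to compound 1 at 43700 nM. The expected step is a 15-fold lower number from compound 2 to compound 3 (1.17 log units; beyond the scatter). For compound 3 the estimated value is 250000 nM, with an expected range of 40000 nM to 1500000 nM.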

Compound 3, dissociation constant: 3630000 nM
Beside the measured number, compound 3's estimate is 15-fold (1.16 log units) below it; measured number outside the range, above it.
By their numbers in this assay, from the lowest: compound 1; then compounds 3 and 2 (each within the scatter of the next).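

In this assay, a 1.0-fold lower number from compound 2 to compound 3 (0.01 log units; within the scatter) is the reading for this change, so the group with one five-membered aromatic ring and the group with two aromatic rings cannot be told apart at this place on a saturated chain carbon bound to a double-bonded ring carbon, even though the entering group carries a hydrogen-bond donor and the leaving group carries none. The second step, an 83-fold higher number from compound 1 to compound 3 (1.92 log units; beyond the scatter) in the same assay, shows that sulfur in the group does not by itself bring the number close to that of compound 1: compound 3 contains sulfur yet remains far from compound 1 and within the scatter of compound 2, which has none. No measurement shown here explains this result.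

The three groups do not show which feature sets compound 1 apart, since it alone has a five-membered aromatic ring with 1 hetero atom alongside a six-membered aromatic ring with 1 hetero atom. A plain pyridine ring at this place, or an amine or a carboxylic acid at the end of the chain in compound 3, would test whether the ring pair or the substituent governs the number.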